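Swapping a Chloro-Trifluoromethyl Ring for Chloro-Methyl

The source may hold more compounds than are shown below. What is called first, only, known or untested is meant among the compounds shown, and "the series" means these compounds.

Compound 1 `CC/C(=C(/c1ccc(/C=C/C(=O)O)cc1)c1cc2ccccc2[nH]1)c1ccc(C(F)(F)F)cc1` gives 139 nM in a functional assay on MCF7 cells (Homo sapiens) for inhibition; on this read-out lower numbers stand for stronger inhibition and higher numbers for weaker inhibition.
Compound 2 `CC/C(=C(/c1ccc(/C=C/C(=O)O)cc1)c1cc2ccccc2[nH]1)c1ccc(C(F)(F)F)cc1Cl` gives 27 nM in this assay.

Compound 2 stands at the lowest of these two numbers, and its distance to compound 1 is beyond the scatter. For the measured compounds named here, the single measured step, a 5.1-fold lower number from compound 1 to compound 2 (0.71 log units; beyond the scatter), describes that gain.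

Compound 3 `CC/C(=C(/c1ccc(/C=C/C(=O)O)cc1)c1cc2ccccc2[nH]1)c1ccc(Cl)c(C)c1` is not yet measured. Its change from compound 2 is 4-chloro-3-methylphenyl in place of 2-chloro-4-(trifluoromethyl)phenyl on a double-bonded chain carbon bound to a double-bonded chain carbon and a saturated chain carbon. Going by the values given here, this is a larger rearrangement than the one measured step: the trifluoromethyl is gone, the chlorine sits at a different ring carbon, and a methyl has arrived. The step of a 5.1-fold lower number from compound 1 to compound 2 (0.71 log units; beyond the scatter) shows that a chloro on this ring can matter, but it says nothing about removing the trifluoromethyl or about a methyl, so that step bears on the change only in part.

With no direct guide for most of the change, the expectation for compound 3 is a somewhat higher number than compound 2, with wide uncertainty, an expected step of a 3.0-fold higher number from compound 2 to compound 3 (0.47 log units; beyond the scatter). The estimate for compound 3 in this assay is 80 nM, expected to fall between 20 nM and 400 nM.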

Compound 3, half-maximal inhibitory concentration: 840 nM
Estimate against measurement, compound 3: 11-fold (1.02 log units) below; the measured number lies above the stated range.
By their numbers in this assay, from the lowest: compound 2; then compound 1; then compound 3.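

For the compounds shown here, the ring on the double-bonded chain carbon can move this read-out much further than the earlier compounds showed: in this assay the change gives a 31-fold higher number from compound 2 to compound 3 (1.49 log units; beyond the scatter), a larger step than the gain seen on adding the chloro. Compound 3 also falls behind compound 1, whose 4-(trifluoromethyl)phenyl ring carries no chloro at all, with a 6.0-fold higher number from compound 1 to compound 3 (0.78 log units; beyond the scatter), so the presence of a chloro on this ring does not by itself give a lower number, and the other groups on the ring and their arrangement count as well. Nothing available here gives a reason for this loss.

The swap removes the trifluoromethyl, moves the chloro and adds a methyl all at once, so these compounds cannot divide the loss among those three changes. A plain 4-chlorophenyl ring, a 2-chloro-4-methylphenyl ring or a 4-chloro-3-methoxyphenyl ring at the same place would help to show which of the three carries the most weight.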